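Ethyl at the 3-Position: Expected Potency of Compound 4

The source may hold more compounds than are shown below. What is called first, only, known or untested is meant among the compounds shown, and "the series" means these compounds.

Compound 1 `Cc1cccc(OC2CCN(c3ccc(-n4ccnc4)nn3)CC2)c1`: 251 nM
Compound 2 `CCc1ccccc1OC1CCN(c2ccc(-n3ccnc3)nn2)CC1`: 4 nM
Compound 3 `COc1ccccc1OC1CCN(c2ccc(-n3ccnc3)nn2)CC1`: 543 nM

In an assay on microsomes from liver for inhibition of acyl-CoA desaturase 1 (Rattus norvegicus) (a lower number here means a stronger inhibitor, a higher number a weaker inhibitor), compound 3 stands weakest of the three measured compounds. The gap to the nearest one is modest, as a 2.2-fold higher number from compound 1 to compound 3 (0.34 log units; beyond the scatter) shows, while the gap to the strongest is large, as a 140-fold higher number from compound 2 to compound 3 (2.13 log units; beyond the scatter) shows. Compound 4 `CCc1cccc(OC2CCN(c3ccc(-n4ccnc4)nn3)CC2)c1` differs from compound 3 by 3-ethylphenyl in place of 2-methoxyphenyl on an oxygen on a saturated carbon. Within the data shown here, two measured steps bear on this. a 63-fold lower number from compound 1 to compound 2 (1.80 log units; beyond the scatter) changes both the group and its place at once, and a 140-fold higher number from compound 2 to compound 3 (2.13 log units; beyond the scatter) shows ethyl far ahead of methoxy at one place. Among the measured compounds shown here, no measured pair compares ethyl with methyl at the same place, so the expected gain is smaller than those steps. Compound 4 is expected at 100 nM, within 15 nM to 600 nM, an expected step of a 5.4-fold lower number from compound 3 to compound 4 (0.73 log units; beyond the scatter).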

Compound 4, half-maximal inhibitory concentration: 38 nM
The estimate for compound 4 lay 2.6-fold (0.42 log units) above the measured number; low and high end bracket the measured number.
By their numbers in this assay, from the lowest: compound 2; then compound 4; then compound 1; then compound 3.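

In this assay, adding one carbon to the methyl group gives a 6.6-fold lower number from compound 1 to compound 4 (0.82 log units; beyond the scatter), the first direct view of what ethyl adds over methyl at a single place on the ring. Moving the ethyl matters as well: 3-ethylphenyl in place of 2-ethylphenyl gives a 9.5-fold higher number from compound 2 to compound 4 (0.98 log units; beyond the scatter), while 3-ethylphenyl in place of 2-methoxyphenyl gives a 14-fold lower number from compound 3 to compound 4 (1.16 log units; beyond the scatter). No evidence is available to explain these differences. Going by these compounds, whether a longer chain such as propyl, or an amine, could replace the ethyl and keep this strength remains open.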